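A Methyl Added to a Compound at the Limit

The compounds below may be only part of what the source reports. "The series", "measured", "known", "first", "only" and "open" are said of these compounds alone.

In a functional assay on the whole organism for agonist activity, with Mus musculus as the target (on this read-out lower numbers stand for an effect already at smaller amounts and higher numbers for an effect only at larger amounts of compound), compound 1 `CC(=O)N(C)C(C)C#CCn1ccnc1` gives 3 mg/kg as a measured number. Compound 2 `CC1CCC(=O)N1CC#CCn1ccnc1` reads > 100 mg/kg in this assay and this is a limit of the assay, not a number. So compound 2 stands at the limit, and no exact value for it is available.

Compound 3 `Cc1cncn1CC#CCN1C(=O)CCC1C` carries one change from compound 2, methyl in place of hydrogen on an aromatic carbon in all, which is methyl in place of hydrogen on an aromatic carbon. Among the measured compounds shown here, no measured pair of compounds shows what such a change does. No step beyond the usual scatter is therefore expected in this assay, in either direction, and compound 3 may well return only a limit again. The estimated change is a step that the limit leaves unreadable from compound 2 to compound 3 and it starts from the limit of compound 2. Compound 3 is expected near 150 mg/kg with an estimated range from 40 mg/kg to 400 mg/kg on the same read-out.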

Compound 3, dose for half-maximal effect: > 100 mg/kg
Compound 3: no number, only a limit (the forecaster's own chance of this, stated with the estimate: 75%); the middle value is on the limit's open side.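

Compound 2 and compound 3 both end at a limit rather than a number, so no step between them can be read in this assay: the limit of > 100 mg/kg in this assay, at which 2 of the 3 values shown sit.

The compounds shown leave open whether methyl in place of hydrogen on an aromatic carbon changes the effect at all in this assay.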